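Swapping the amide aryl group on a shared core

This account rests on a few compounds, and the source may have more. Where it says the series, first, only, none or still open, it means among the compounds named here.

The three measured compounds share one core and differ at two places. Compound 1 `COc1cc2c(Nc3nc4ccc(C(=O)Nc5c(C)cc(C)cc5C)cc4s3)ncnc2cc1OCCCN1CCCCC1C` gives 3500 nM in a functional assay on K562 cells (Homo sapiens) for cytotoxicity, read by WST assay, with a stated time of 72 h; on this read-out lower numbers stand for stronger inhibition and higher numbers for weaker inhibition. Compound 2 `CCN(CC)CCCOc1cc2ncnc(Nc3nc4ccc(C(=O)Nc5c(C)cc(C)cc5C)cc4s3)c2cc1OC` gives 6800 nM. Among the measured compounds shown here, the step of a 1.9-fold higher number from compound 1 to compound 2 (0.29 log units; within the scatter) is the only single-point comparison among the measured compounds, and it concerns the amine on the chain, not the amide aryl group. Compound 3 `COc1cc2c(Nc3nc4ccc(C(=O)Nc5c(C)cccc5Cl)cc4s3)ncnc2cc1OCCCN1CCCC1` gives 13300 nM, the highest of the three numbers; it lies within the scatter of compound 2 but beyond it relative to compound 1.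

Compound 4 `COc1cc2c(Nc3nc4ccc(C(=O)Nc5c(C)cc(C)cc5C)cc4s3)ncnc2cc1OCCCN1CCCC1` differs from compound 3 by 2,4,6-trimethylphenyl in place of 2-chloro-6-methylphenyl on an amide-type nitrogen. For the measured compounds named here, no measured step covers this change directly. What the data do show is that compound 1 and compound 2, both carrying the 2,4,6-trimethylphenyl group, return lower numbers than compound 3. On that basis a modestly lower number is expected for compound 4, an estimated step of a 2.4-fold lower number from compound 3 to compound 4 (0.38 log units; beyond the scatter). Compound 4 is therefore expected to give about 5500 nM, within a range from 2200 nM to 13000 nM.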

Compound 4, half-maximal inhibitory concentration: 4300 nM
The estimate for compound 4 lay 1.3-fold (0.11 log units) above the measured number; low and high end bracket the measured number.
By their numbers in this assay, from the lowest: compounds 1, 4, 2 and 3 (each within the scatter of the next, the first and the last beyond it).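

In this assay, among the compounds shown here, the change from 2-chloro-6-methylphenyl to 2,4,6-trimethylphenyl on the amide-type nitrogen now has a direct measurement, a 3.1-fold lower number from compound 3 to compound 4 (0.49 log units; beyond the scatter), a step beyond the scatter that the earlier compounds could not supply. With 2,4,6-trimethylphenyl held constant, pyrrolidin-1-yl on the chain is not told apart from diethylamino, a 1.6-fold lower number from compound 2 to compound 4 (0.20 log units; within the scatter), or from 2-methylpiperidin-1-yl, a 1.2-fold higher number from compound 1 to compound 4 (0.09 log units; within the scatter), as both steps lie within the scatter. Nothing available accounts for the step at the amide-type nitrogen.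

The compounds shown leave open whether that step follows the loss of chlorine or the gain of methyl, which a 2,6-dimethylphenyl group on the same nitrogen could help to separate. They also leave open whether it would hold with an amine other than pyrrolidin-1-yl on the chain, such as morpholin-4-yl.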